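Swapping the urea tail: from basic chain to amide-linked ring

The source may report more compounds than this note shows. Statements on the series, on what has been measured and on what is new or still open speak of the compounds shown alone.

Compound 3 `COc1ncc(-c2ccc3nc(NC(=O)NCCN4CCN(C)CC4)nn3c2)cc1NS(=O)(=O)c1ccc(F)cc1` gives 1050 nM in a functional assay on A549 cells (Homo sapiens) for cytotoxicity, read by MTT assay, with a stated time of 72 h (on this read-out higher numbers stand for weaker inhibition and lower numbers for stronger inhibition), the second highest of the three numbers. Compound 2 `COc1ncc(-c2ccc3nc(NC(=O)NC4CC4)nn3c2)cc1NS(=O)(=O)c1ccc(F)cc1` gives 210 nM, and compound 1 `COc1ncc(-c2ccc3nc(NC(=O)N4CCCC4)nn3c2)cc1NS(=O)(=O)c1ccc(F)cc1` gives 3570 nM. Compound 4 `COc1ncc(-c2ccc3nc(NC(=O)NCC(=O)N4CCCCC4)nn3c2)cc1NS(=O)(=O)c1ccc(F)cc1` differs from compound 3 by (piperidin-1-yl)carbonyl in place of (4-methylpiperazin-1-yl)methyl on a saturated chain carbon bound to an amide-type nitrogen. Among the measured compounds shown here, no measured step changes the same piece; the nearest guides are a 5.0-fold higher number from compound 2 to compound 3 (0.70 log units; beyond the scatter) and a 3.4-fold lower number from compound 1 to compound 3 (0.53 log units; beyond the scatter), which show that variation at the urea nitrogen moves this read-out by modest amounts in either direction. The group entering compound 4 is of similar size to the one leaving, so only a modest step is expected in this assay, direction uncertain, a 1.1-fold higher number from compound 3 to compound 4 (0.06 log units; within the scatter). Compound 4 is therefore estimated at 1200 nM, with a range from 350 nM to 4000 nM.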

Compound 4, half-maximal inhibitory concentration: 2060 nM
Compound 4: the middle estimate sits 1.7-fold (0.23 log units) below what was measured; measured number inside the range.
By their numbers in this assay, from the lowest: compound 2; then compounds 3, 4 and 1 (each within the scatter of the next, the first and the last beyond it).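

In this assay the exchange of (4-methylpiperazin-1-yl)methyl for (piperidin-1-yl)carbonyl on this saturated chain carbon stays within the scatter (a 2.0-fold higher number from compound 3 to compound 4 (0.29 log units; within the scatter)), and so does the step from the pyrrolidin-1-yl compound (a 1.7-fold lower number from compound 1 to compound 4 (0.24 log units; within the scatter)). Among the compounds shown here, only the step from the cyclopropyl compound lies beyond it (a 9.8-fold higher number from compound 2 to compound 4 (0.99 log units; beyond the scatter)), so compound 2 remains apart from the other three. Nothing measured here accounts for these steps.

From the compounds shown here alone, whether a dimethylamino group or a carboxylic acid in place of the (piperidin-1-yl)carbonyl, or a longer chain carrying it, would come closer to compound 2 stays open.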